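The source may hold more compounds than are shown below. What is called first, only, known or untested is meant among the compounds shown, and "the series" means these compounds.

In an ADME assay on the whole organism (plasma) for pharmacokinetics, with Rattus norvegicus as the target, at a dose of 3 mg/kg by the oral route (on this read-out lower numbers stand for lower exposure and higher numbers for higher exposure at the dose given), compound 1, `CC(=O)Nc1cc(C(=O)O)cc(-n2c(C)ccc2-c2cc(Br)ccc2OCc2ccc(F)cc2F)c1`, gives 350000000 ng.h/mL, the highest of the three numbers in this set. Compound 3, `CC(=O)Nc1cc(C(=O)O)cc(-n2c(C)ccc2-c2cc(Cl)ccc2OCc2ccc(F)cc2)c1`, gives 333000000 ng.h/mL in this assay, a number that sits within the usual scatter of the value for compound 1, so the two cannot be told apart. Compound 2, `Cc1ccc(-c2cc(Cl)ccc2OCc2ccc(F)cc2F)n1-c1cc(C(=O)O)ccc1F`, gives 66700000 ng.h/mL in this assay, and the gap from compound 1 down to compound 2 is beyond the scatter.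

The next compound to be measured is compound 4, `Cc1ccc(-c2cc(Br)ccc2OCc2ccc(F)cc2F)n1-c1cc(N)cc(C(=O)O)c1`, which is built from compound 1 by one change: hydrogen in place of acetyl on a nitrogen on an aromatic ring. Within the data shown here, no pair of measured compounds differs in this way, so nothing in the set shows what this change does.

Compound 4 is therefore expected to lie close to compound 1, with the step of a 1.4-fold lower number from compound 1 to compound 4 (0.15 log units; within the scatter) in this assay not expected to go beyond the scatter. For compound 4 the estimate in this assay is 250000000 ng.h/mL, in a range from 80000000 ng.h/mL to 600000000 ng.h/mL.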

Compound 4, area under the concentration-time curve: < 16700000 ng.h/mL
Compound 4: no number, only a limit; the forecaster's own chance of this, stated with the estimate: 2%; middle value at least 14-fold (1.17 log units) from the limit.
By their numbers in this assay, from the lowest: compound 2; then compounds 3 and 1 (each within the scatter of the next). At a limit, below all of these: compound 4.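

Among these compounds, this is the first step in the set that changes one place only: in this assay, replacing acetamido with amino on the aromatic ring gives an at least 20-fold lower number from compound 1 to compound 4 (1.32 log units; beyond the scatter). Among the compounds shown here, for this pair, the acetyl on this nitrogen therefore makes a large difference to exposure, a difference that the earlier compounds could not show. The step is a bound and not an exact size, and the real gap may be wider: the limit of < 16700000 ng.h/mL in this assay, at which 1 of the 4 values shown sits.

On these data alone, it remains open whether another group on this nitrogen, such as a formyl, a propanoyl or a methanesulfonyl, would keep the exposure of compound 1 or whether it would fall as it does with the bare amino. As far as these compounds go, the evidence rests on a single pair, so it also remains open whether the same change would have the same effect on the core of compound 3.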